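This account rests on a few compounds, and the source may have more. Where it says the series, first, only, none or still open, it means among the compounds named here.

In an ADME assay on MT4 cells (Homo sapiens) for cytotoxicity, read by spectrophotometry, with a stated time of 5 days (on this read-out higher numbers stand for lower toxicity in this test and lower numbers for higher toxicity in this test), compound 1 `Cc1ccc2c(c1)/C(=N/NC(=S)NO)C(=O)N2CN(C)C` gives 651000 nM, compound 2 `CN(C)CN1C(=O)/C(=N\NC(=S)NO)c2cc(F)ccc21` gives 599000 nM and compound 3 `CONC(=S)N/N=C1\C(=O)N(CN(C)C)c2ccc(C)cc21` gives 622000 nM. Compound 1 therefore stands level with both, all three lying within the scatter. Compound 4 `CCN(CC)CN1C(=O)/C(=N\NC(=S)NO)c2cc(C)ccc21` differs from compound 1 by diethylamino in place of dimethylamino on a saturated chain carbon bound to an amide-type nitrogen in a ring, on a saturated chain carbon bound to an amide-type nitrogen in a ring. Among the compounds with values here, no measured step touches that place. The nearest evidence is indirect: fluoro in place of methyl on an aromatic carbon gives a 1.1-fold lower number from compound 1 to compound 2 (0.04 log units; within the scatter), and methyl in place of hydrogen on an oxygen gives a 1.0-fold lower number from compound 1 to compound 3 (0.02 log units; within the scatter). Both are small, so nothing beyond the scatter is expected in this assay. The expected change is a 1.2-fold lower number from compound 1 to compound 4 (0.07 log units; within the scatter). For compound 4 the estimate is 560000 nM, with an expected range of 300000 nM to 900000 nM.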

Compound 4, half-maximal cytotoxic concentration: 534000 nM
Compound 4: middle estimate off by 1.0-fold (0.02 log units), on the high side, and the stated range covers the measured number.
By their numbers in this assay, from the lowest: compounds 4, 2, 3 and 1 (each within the scatter of the next).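

In this assay, within the data shown here, this is the first direct reading at this position: diethylamino in place of dimethylamino on a saturated chain carbon bound to an amide-type nitrogen in a ring (a 1.2-fold lower number from compound 1 to compound 4 (0.09 log units; within the scatter)). Enlarging this group from 3 to 5 heavy atoms therefore stays within the scatter, as did the two earlier single changes elsewhere on the molecule. No measured evidence bears on this result.

Going by these compounds, whether morpholine or piperidine at this place, or a longer chain, would also stay within the scatter remains open. Also open, on these data alone, is whether diethylamino gives the same result alongside fluoro on the aromatic carbon.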